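Deoxyuridine-derived cytotoxins on PC-3: pentyl to 4-butylphenyl

The source may hold more compounds than are shown below. What is called first, only, known or untested is meant among the compounds shown, and "the series" means these compounds.

Measured so far:
- compound 1, `CCCCCc1cc(-c2cn([C@H]3C[C@H](OC(C)=O)[C@@H](COC(C)=O)O3)c(=O)[nH]c2=O)on1`: 93.9%
- compound 2, `CC(=O)OC[C@H]1O[C@@H](n2cc(-c3cn(Cc4ccc(C(C)(C)C)cc4)nn3)c(=O)[nH]c2=O)C[C@@H]1OC(C)=O`: 90.4%

Both compounds were run in a functional assay on PC-3 cells (Homo sapiens) for cytotoxicity, read by sulforhodamine B assay, tested at 10 uM; a higher number here means more inhibition at the concentration tested (going by the name of the read-out), a lower number less inhibition. Compound 1 gives 93.9%, the highest of the two numbers, while compound 2 gives 90.4%; the gap between them lies within the scatter, so no order between compound 1 and compound 2 can be read from these two values. Going by the values given here, no pair differing in a single place has been measured, so no step size is yet known for this series.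

Compound 3, `CCCCc1ccc(-c2cc(-c3cn([C@H]4C[C@H](OC(C)=O)[C@@H](COC(C)=O)O4)c(=O)[nH]c3=O)on2)cc1`, is not yet measured in this assay. It differs from compound 1 as follows: 4-butylphenyl in place of pentyl on an aromatic carbon

With compound 1 already near the top of the scale in this assay, the room for a rise is small. The expectation is a step of a number 5.9 percentage points lower from compound 1 to compound 3 (within the scatter) of no more than the usual scatter, in either direction. Compound 3 is therefore estimated to give 88% in this assay, with a likely range from 70% to 98%.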

Compound 3, a percentage reported as inhibition, at one concentration (the size of the read-out at that concentration, not a potency): 30.4%
Estimate against measurement, compound 3: 57.6 percentage points above, and the stated range ends above it.
By their numbers in this assay, from the lowest: compound 3; then compounds 2 and 1 (each within the scatter of the next).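

In this assay, going by these compounds alone, placing 4-butylphenyl instead of pentyl on the aromatic carbon next to the ring nitrogen gives a number 63.5 percentage points lower from compound 1 to compound 3 (beyond the scatter) and is the first single-place step. The position is therefore not indifferent to the group it carries: the high reading of compound 1 does not carry over to this larger ring-bearing group, which has 10 heavy atoms and one six-membered aromatic ring where pentyl has 5 heavy atoms and no ring. No measurement at hand bears on the cause of this drop.

The pair changes the ring and the heavy-atom count together, so it leaves open whether the aromatic ring, the overall size or the butyl tail on the ring accounts for the loss; an unsubstituted phenyl, a longer chain such as decyl or a pentyl chain ending in an amine at the same place would help to separate these. Compound 2 differs from compound 1 and compound 3 in more than one place, so it adds nothing on this position.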